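Replacing chloro with methoxy: what to expect

A few compounds are considered here, and "the series" means these few. Any claim that something is new, unique, unknown or untested is made for them only; others in the source may bear on it.

Three compounds share one core and differ only in the halogen-bearing phenyl group. In an ADME assay on WI-38 cells (Homo sapiens) for cytotoxicity, read by MTT assay, with a stated time of 72 h (on this read-out higher numbers stand for weaker inhibition and lower numbers for stronger inhibition), compound 1 `O=C(CCc1cccc2c1B(O)OC2)Nc1cccc(-c2cccc(F)c2)c1` gives 37000 nM, compound 2 `O=C(CCc1cccc2c1B(O)OC2)Nc1cccc(-c2ccc(F)cc2)c1` gives 4100 nM, and compound 3 `O=C(CCc1cccc2c1B(O)OC2)Nc1cccc(-c2ccc(Cl)cc2)c1` gives 9800 nM. Compound 3 therefore has the second highest of the three numbers.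

Compound 4 `COc1ccc(-c2cccc(NC(=O)CCc3cccc4c3B(O)OC4)c2)cc1` has not yet been measured. It carries 4-methoxyphenyl in place of the 4-chlorophenyl of compound 3: methoxy in place of chloro on an aromatic carbon.

The closest guide is the exchange at the same place, a 2.4-fold higher number from compound 2 to compound 3 (0.38 log units; beyond the scatter), with chloro in place of fluoro. The larger steps, a 9.0-fold lower number from compound 1 to compound 2 (0.96 log units; beyond the scatter) and a 3.8-fold lower number from compound 1 to compound 3 (0.58 log units; beyond the scatter), both start from 3-fluorophenyl, a group absent from compound 4, so they bear on it less. For the measured compounds named here, no measured step involves methoxy, so the direction stays open. In this assay, no step beyond the scatter is expected. The expected change is a 1.2-fold lower number from compound 3 to compound 4 (0.09 log units; within the scatter). For compound 4, the estimated value is 8000 nM, with an expected range from 3000 nM to 22000 nM.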

Compound 4, half-maximal inhibitory concentration: 1400 nM
Compound 4: the middle estimate sits 5.7-fold (0.76 log units) above what was measured, outside the stated range (below it).
By their numbers in this assay, from the lowest: compound 4; then compound 2; then compound 3; then compound 1.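

At this place, on an aromatic carbon para to a large group, a swap between halogens had shown only a small change, whereas in this assay methoxy in place of chloro gives a 7.0-fold lower number from compound 3 to compound 4 (0.85 log units; beyond the scatter) and so reaches beyond both halogens at this place. Methoxy in place of fluoro likewise gives a 2.9-fold lower number from compound 2 to compound 4 (0.47 log units; beyond the scatter) here, and the change from 3-fluorophenyl to 4-methoxyphenyl gives a 26-fold lower number from compound 1 to compound 4 (1.42 log units; beyond the scatter) as the widest step in the set, leaving compound 4 with the lowest number of the four and therefore the strongest effect on these cells. No measurement is available to explain why methoxy differs from the halogens here.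

Still open, as far as these compounds go, is whether a hydroxy group, a longer ethoxy chain or an amine at this place would lower the number further or raise it again. Also open, from the compounds shown here alone, is whether methoxy would give a similar result at the place held by fluoro in compound 1.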